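Carboxymethyl on the Ring Nitrogen: Cytotoxicity Still at the Limit

The compounds below may be only part of what the source reports. "The series", "measured", "known", "first", "only" and "open" are said of these compounds alone.

Measured so far in a toxicity assay on A549 cells (Homo sapiens) for cytotoxicity, read by MTT assay, with a stated time of 48 h; a lower number here means a stronger inhibitor of growth, a higher number a weaker inhibitor of growth:
- Compound 1 `Cc1cccc2cc(/C=C3\SC(=S)NC3=O)c(Cl)nc12` gives only a limit, > 100 ug/mL.
- Compound 2 `O=C1NC(=S)S/C1=C\c1cc2cc(F)ccc2nc1Cl` gives only a limit, > 100 ug/mL.
- Compound 3 `Cc1cccc2cc(/C=C3\SC(=S)N(CC(=O)O)C3=O)c(Cl)nc12` gives only a limit, > 100 ug/mL.

None of these three is a number: each sits at the limit of > 100 ug/mL in this assay, at which 3 of the 3 values shown sit. Compound 1 and compound 3 share a core and differ in one place, (carboxymethyl in place of hydrogen on an amide-type nitrogen in a ring). The step that the two limits leave unreadable from compound 1 to compound 3 therefore cannot be read, since both ends are limits. Compound 2 has a different core from compound 1; that difference is not broken down here.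

Compound 4 `O=C(O)CN1C(=O)/C(=C/c2cc3cc(F)ccc3nc2Cl)SC1=S` has not yet been measured in this assay. It stands to compound 2 exactly as compound 3 stands to compound 1: carboxymethyl in place of hydrogen on an amide-type nitrogen in a ring, the same change at the same place. The step that the limit leaves unreadable from compound 2 to compound 4 is expected to be small, because the limit of > 100 ug/mL in this assay, at which 3 of the 3 values shown sit, is where all three measured values rest. In particular the expectation rests on the unreadable step that the two limits leave unreadable from compound 1 to compound 3. Compound 4 is therefore estimated at 150 ug/mL, most likely reported as a limit again, with a range from 60 ug/mL to 400 ug/mL.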

Compound 4, concentration for 50% growth inhibition: > 100 ug/mL
Compound 4 was reported as a limit (the forecaster's own chance of this, stated with the estimate: 85%); the middle value lies beyond the limit too.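

Compound 2 and compound 4 both end at a limit and not at a number, so the step between them cannot be read, because there is no measured value at either end: the limit of > 100 ug/mL in this assay, at which 4 of the 4 values shown sit.

The compounds shown leave open how strongly any of them inhibits growth in this assay, and whether carboxymethyl on the ring nitrogen changes that at all.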